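Moving the Trifluoromethyl Group on a Second Pair of Phenols

A few compounds are considered here, and "the series" means these few. Any claim that something is new, unique, unknown or untested is made for them only; others in the source may bear on it.

Compound 1 `Oc1ccccc1-c1cc(-c2ccccc2C(F)(F)F)cc(-c2ccccc2O)n1` — 4770 nM
Compound 2 `Oc1ccccc1-c1cc(-c2cccc(C(F)(F)F)c2)cc(-c2ccccc2O)n1` — > 50000 nM
Compound 3 `Oc1cccc(-c2cc(-c3ccccc3C(F)(F)F)cc(-c3cccc(O)c3)n2)c1` — 2870 nM

In a functional assay on DU-145 cells (Homo sapiens) for inhibition (on this read-out lower numbers stand for stronger inhibition and higher numbers for weaker inhibition), compound 1 gives 4770 nM. Compound 2 reaches only a limit of the assay, > 50000 nM, and so has no number of its own. Between them lies the change (3-(trifluoromethyl)phenyl in place of 2-(trifluoromethyl)phenyl on an aromatic carbon), which produced an at least 10-fold higher number from compound 1 to compound 2 (1.02 log units; beyond the scatter); the size of that step is bounded by the limit of > 50000 nM in this assay, at which 1 of the 3 values shown sits, so its true extent is not known. Compound 3 gives 2870 nM in this assay, a value within the scatter of compound 1, so no order between the two can be claimed. The difference between the two cores of compound 1 and compound 3 is not broken down here.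

Compound 4 `Oc1cccc(-c2cc(-c3cccc(C(F)(F)F)c3)cc(-c3cccc(O)c3)n2)c1` is not yet measured. It differs from compound 3 by 3-(trifluoromethyl)phenyl in place of 2-(trifluoromethyl)phenyl on an aromatic carbon. This is the same kind of change as that from compound 1 to compound 2, but not the same: there the place was meta to two 2-hydroxyphenyl groups, here it is meta to two 3-hydroxyphenyl groups. Going by the values given here, from compound 3 to compound 4 a large weakening step is expected, a 10-fold higher number from compound 3 to compound 4 (1.02 log units; beyond the scatter), resting on the single earlier example an at least 10-fold higher number from compound 1 to compound 2 (1.02 log units; beyond the scatter) and on compound 3 giving 2870 nM. Among the compounds with values here, with only one precedent, and that one a limit, the expected value for compound 4 in this assay is 30000 nM, within 8000 nM to 60000 nM, and a limit rather than a number is a real possibility.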

Compound 4, half-maximal inhibitory concentration: > 50000 nM
Compound 4 ended at the assay's limit (the forecaster's own chance of this, stated with the estimate: 40%); middle value at least 1.6-fold (0.22 log units) from the limit.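

In this assay compound 4 reaches only a limit of the assay, > 50000 nM, and so has no number of its own. With 3-(trifluoromethyl)phenyl in place of 2-(trifluoromethyl)phenyl on the core bearing two 3-hydroxyphenyl groups, the result is an at least 17-fold higher number from compound 3 to compound 4 (1.24 log units; beyond the scatter), so the large weakening seen on the core of compound 1 also appears on this second core, and the change goes the same way in both pairs: the same change on two cores in this assay, an at least 10-fold higher number (1.02 log units; beyond the scatter) from compound 1 to compound 2 and an at least 17-fold higher number (1.24 log units; beyond the scatter) from compound 3 to compound 4; the limit leaves it open whether they differ. Going by these compounds alone, this does not give the true size of either step, does not show that one core responds more strongly than the other, and rests on only two pairs, with compound 2 and compound 4 both at the limit: the limit of > 50000 nM in this assay, at which 2 of the 4 values shown sit.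

The compounds shown leave open whether the weakening belongs to the 3-(trifluoromethyl)phenyl group alone or would also follow other groups in that place, such as a methoxy group, a nitrile or an amine on the phenyl ring. They also leave open whether the same step would hold on a core in which a methoxy group or an amine takes the place of the hydroxyl groups.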